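Trimming a Methyl from the Alkyne Side Chain

The source may report more compounds than this note shows. Statements on the series, on what has been measured and on what is new or still open speak of the compounds shown alone.

Measured so far:
- compound 1, `NC(=O)c1cc(Cl)c2c(Cl)c(C#CCCO)n([C@H]3CCCNC3)c2n1`: 56 nM
- compound 2, `CC(O)C#Cc1c(Cl)c2c(Cl)cc(C(N)=O)nc2n1[C@H]1CCCNC1`: 147 nM

Both compounds share one core and were tested in a functional assay on KG-1 cells (Homo sapiens) for antiproliferative activity; a higher number here means that more compound is needed for the effect, a lower number that less compound is needed. Within the data shown here, compound 2 stands highest of the two numbers; its nearest neighbour is compound 1, and the single measured step between them, a 2.6-fold higher number from compound 1 to compound 2 (0.42 log units; beyond the scatter), came with 1-hydroxyethyl in place of 2-hydroxyethyl on a triple-bonded carbon. That step moved the hydroxyl along the chain rather than shortening it.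

Compound 3, `NC(=O)c1cc(Cl)c2c(Cl)c(C#CCO)n([C@H]3CCCNC3)c2n1`, differs from compound 2 by hydrogen in place of methyl on a saturated chain carbon bound to an oxygen on a saturated carbon and a triple-bonded carbon. Among the measured compounds shown here, no measured step removes a methyl at this place, so the only guidance is that the side chain on the triple-bonded carbon clearly matters, as the step between compound 1 and compound 2 shows, and that compound 3 ends up as a chain shorter than either. A modest move back toward the lower number of compound 1 seems the likeliest outcome, but it may well stay within the scatter.

Compound 3 is therefore estimated at 90 nM, with a range from 35 nM to 230 nM. This estimate corresponds to an expected 1.6-fold lower number from compound 2 to compound 3 (0.21 log units; within the scatter).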

Compound 3, half-maximal effective concentration: 301 nM
Beside the measured number, compound 3's estimate is 3.3-fold (0.52 log units) below it; measured number above the stated range.
By their numbers in this assay, from the lowest: compound 1; then compound 2; then compound 3.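

In this assay, taking the methyl off 1-hydroxyethyl to leave hydroxymethyl gives a 2.0-fold higher number from compound 2 to compound 3 (0.31 log units; beyond the scatter), so the change does not recover the lower number of compound 1, and the methyl at this place goes with less compound being needed, not more. The second new comparison puts hydroxy in place of hydroxymethyl on the saturated chain carbon bound to a triple-bonded carbon and gives a 5.4-fold higher number from compound 1 to compound 3 (0.73 log units; beyond the scatter), so among these three compounds the 3-hydroxyprop-1-yn-1-yl chain stands at the highest number, and either way of adding to it, as the branching methyl of compound 2 or as the longer chain of compound 1, comes with a lower number, the longer chain with the lower of the two. Nothing given here accounts for these differences.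

On these data alone, whether a still longer chain would lower the number further, or would reverse the trend, remains open. Also open, as far as these compounds go, is what happens when the hydroxyl at the end of the chain gives way to an amine or a methyl ether, and so whether the oxygen itself is needed at all.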